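Ethyl ester series: replacing the 3-methoxybenzyl group

This account rests on a few compounds, and the source may have more. Where it says the series, first, only, none or still open, it means among the compounds named here.

Compound 1 `CCOC(=O)c1ccc(-c2nn(Cc3ccc(Cl)cc3)c3ccccc23)cc1`: > 10000 nM, a limit
Compound 2 `CCOC(=O)c1ccc(-c2nn(Cc3ccccc3F)c3ccccc23)cc1`: > 10000 nM, a limit
Compound 3 `CCOC(=O)c1ccc(-c2nn(Cc3cccc(OC)c3)c3ccccc23)cc1`: > 10000 nM, a limit

The measurements come from a functional assay on cells (Platelet, Homo sapiens) for inhibition; a higher number here means a weaker inhibitor, a lower number a stronger inhibitor. In this assay compound 3 gives > 10000 nM, which is a limit and not a number. Among the compounds with values here, it has no readable position relative to the other two compounds, and the whole series so far comes down to one reading: the limit of > 10000 nM in this assay, at which 3 of the 3 values shown sit.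

The next compound is compound 4 `CCOC(=O)c1ccc(-c2nn(Cc3cccnc3)c3ccccc23)cc1`, not yet measured. It carries pyridin-3-yl in place of 3-methoxyphenyl on a saturated chain carbon bound to an aromatic nitrogen.

Within the data shown here, three measured steps bear on this change, all made at the same place: a step that the two limits leave unreadable from compound 1 to compound 2, a step that the two limits leave unreadable from compound 1 to compound 3 and a step that the two limits leave unreadable from compound 2 to compound 3. Among the measured compounds shown here, none of them has a readable size, so they offer no measured step to carry over to the new group. What they do show is that three different aryl groups at this place all end at the limit. The same outcome is therefore the likeliest one here, and no direction of change can be expected in this assay. The expected step is a step that the limit leaves unreadable from compound 3 to compound 4. Compound 4 is estimated at 12000 nM, with an expected range from 3000 nM to 40000 nM.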

Compound 4, half-maximal inhibitory concentration: > 10000 nM
Compound 4 ended at the assay's limit; the forecaster's own chance of this, stated with the estimate: 75%; the middle value lies beyond the limit too.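

In this assay compound 4 gives > 10000 nM, which is a limit and not a number. No new step can be read among compound 1, compound 2, compound 3 and compound 4, and the series stays at one reading: the limit of > 10000 nM in this assay, at which 4 of the 4 values shown sit.

The compounds shown leave open whether any group on this saturated chain carbon bound to an aromatic nitrogen gives a readable value.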